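Amine nitrogen substituent swap: compound 3 to compound 4

The source may report more compounds than this note shows. Statements on the series, on what has been measured and on what is new or still open speak of the compounds shown alone.

Of the compounds shown here, three sharing one core have been measured in an assay on CHO cells for displacement of a labelled ligand from 5-hydroxytryptamine receptor 1B (Homo sapiens); a higher number here means a weaker inhibitor, a lower number a stronger inhibitor. Compound 1 `O=S(=O)(NCC1CCN(CCCc2c[nH]c3ccc(-n4cnnc4)cc23)CC1)c1ccccc1` gives 60 nM. Compound 2 `CN(C1CCN(CCCc2c[nH]c3ccc(-n4cnnc4)cc23)CC1)S(=O)(=O)c1ccccc1` gives 10 nM in this assay, and compound 3 `CC(=O)Nc1ccc([C@H](C)NCC2CCN(CCCc3c[nH]c4ccc(-n5cnnc5)cc34)CC2)cc1` gives 9.3 nM. Compound 3 holds the lowest of the three numbers; its gap to compound 2 lies within the scatter, while a 6.5-fold lower number from compound 1 to compound 3 (0.81 log units; beyond the scatter) lies beyond it, as does a 6.0-fold lower number from compound 1 to compound 2 (0.78 log units; beyond the scatter).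

Compound 4 `c1ccc2c(c1)CCC2NCC1CCN(CCCc2c[nH]c3ccc(-n4cnnc4)cc23)CC1` is not yet measured. Relative to compound 3 the change is 2,3-dihydro-1H-inden-1-yl in place of 1-(4-acetamidophenyl)ethyl on an amine nitrogen. Going by the values given here, the only measured step touching the same amine nitrogen is a 6.5-fold lower number from compound 1 to compound 3 (0.81 log units; beyond the scatter), which exchanged a phenylsulfonyl for the group now leaving. Among the compounds with values here, the present exchange keeps a six-membered aromatic ring of carbon only, but the entering group carries no hydrogen-bond donor or acceptor, and no measured pair tests that exchange directly. A small step in this assay is expected for compound 4, a 1.6-fold higher number from compound 3 to compound 4 (0.21 log units; within the scatter), toward a higher number if any. Compound 4 is estimated at 15 nM in this assay, with a range from 5 nM to 50 nM.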

Compound 4, half-maximal inhibitory concentration: 25 nM
Estimate against measurement, compound 4: 1.7-fold (0.22 log units) below; measured number inside the range.
By their numbers in this assay, from the lowest: compounds 3 and 2 (each within the scatter of the next); then compound 4; then compound 1.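

In this assay, replacing 1-(4-acetamidophenyl)ethyl on the amine nitrogen with 2,3-dihydro-1H-inden-1-yl, which has no hydrogen-bond donor or acceptor, gives a modest loss beyond the scatter (a 2.7-fold higher number from compound 3 to compound 4 (0.43 log units; beyond the scatter)). The same entering group still gives a lower number than phenylsulfonyl on that nitrogen (a 2.4-fold lower number from compound 1 to compound 4 (0.38 log units; beyond the scatter)), so the three groups at this position now fall in a clear order, with 1-(4-acetamidophenyl)ethyl lowest and phenylsulfonyl highest. Compound 4 also separates from the sulfonamide compound 2 (a 2.5-fold higher number from compound 2 to compound 4 (0.40 log units; beyond the scatter)), a step that exchanges the whole substituent on the saturated ring carbon.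

Nothing available accounts for these gaps.

Still open, as far as these compounds go, is how 1-(4-aminophenyl)ethyl or 1-(4-carboxyphenyl)ethyl on the same amine nitrogen would compare with 1-(4-acetamidophenyl)ethyl, and whether the opposite configuration at its defined stereocentre changes the number.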